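A few compounds are considered here, and "the series" means these few. Any claim that something is new, unique, unknown or untested is made for them only; others in the source may bear on it.

Compounds measured in an assay on microsomes from liver for inhibition of 3-hydroxy-3-methylglutaryl-coenzyme A reductase (Rattus norvegicus); a higher number here means a weaker inhibitor, a lower number a stronger inhibitor:
compound 1, `CC(C)c1c(C(=O)NCc2ccccc2)nn(-c2ccc(F)cc2)c1OC[C@@H](O)C[C@@H](O)CC(=O)O`: 3.8 nM
compound 2, `COc1ccc(CNC(=O)c2nn(-c3ccc(F)cc3)c(OC[C@@H](O)C[C@@H](O)CC(=O)O)c2C(C)C)cc1`: 12 nM
compound 3, `CC(C)c1c(C(=O)NCc2ccc(Cl)cc2)nn(-c2ccc(F)cc2)c1OC[C@@H](O)C[C@@H](O)CC(=O)O`: 6.7 nM

Compound 3 holds the second highest of the three numbers, but its separation from compound 1, a 1.8-fold higher number from compound 1 to compound 3 (0.25 log units; within the scatter), and from compound 2, a 1.8-fold lower number from compound 2 to compound 3 (0.25 log units; within the scatter), both lie within the scatter, so no order among the three is established. Compound 4, `CC(C)c1c(C(=O)N(C)Cc2ccc(F)cc2)nn(-c2ccc(F)cc2)c1OC[C@@H](O)C[C@@H](O)CC(=O)O`, differs from compound 3 by (4-fluorobenzyl)(methyl)amino in place of (4-chlorobenzyl)amino on a carbonyl carbon. Going by the values given here, the two measured steps that touch the same aromatic carbon show only small movement when chloro replaces hydrogen or methoxy; no measured step addresses the loss of the hydrogen-bond donor on the amide nitrogen. A small weakening is therefore expected, with wide uncertainty. Compound 4 is expected to give about 14 nM, between 4 nM and 50 nM. The expected step is a 2.1-fold higher number from compound 3 to compound 4 (0.32 log units; beyond the scatter).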

Compound 4, half-maximal inhibitory concentration: 18 nM
The estimate for compound 4 lay 1.3-fold (0.11 log units) below the measured number, and the stated range covers the measured number.
By their numbers in this assay, from the lowest: compounds 1, 3, 2 and 4 (each within the scatter of the next, the first and the last beyond it).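

Going by these compounds alone, putting (4-fluorobenzyl)(methyl)amino on the carbonyl carbon removes the amide hydrogen, and this is the first change to reach beyond the aromatic carbon substituents. It gives a modest rise against the chloro compound (a 2.7-fold higher number from compound 3 to compound 4 (0.43 log units; beyond the scatter)) and against the unsubstituted benzyl compound (a 4.7-fold higher number from compound 1 to compound 4 (0.68 log units; beyond the scatter)), but stays within the scatter against the methoxy compound (a 1.5-fold higher number from compound 2 to compound 4 (0.18 log units; within the scatter)). No evidence bears on the cause of these steps.

Fluoro for chloro and methyl for the amide hydrogen change together, so their separate contributions remain unresolved. Open too, going by these compounds, is how an ethyl group or a longer chain on that nitrogen would behave.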